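Carboxy to carbamoyl in the platelet series

This account rests on a few compounds, and the source may have more. Where it says the series, first, only, none or still open, it means among the compounds named here.

Measured in a functional assay on cells (Platelet, Homo sapiens) for inhibition (on this read-out higher numbers stand for weaker inhibition and lower numbers for stronger inhibition), as follows
- compound 1 `CCOC(=O)c1cccc(-c2n[nH]c3ccccc23)c1` gives 5650 nM
- compound 2 `CCCCn1nc(-c2ccc(C(=O)OCC)cc2)c2ccccc21` gives 670 nM
- compound 3 `O=C(O)c1ccc(-c2nn(Cc3ccccc3)c3ccccc23)cc1` gives > 10000 nM (a limit, not a number)

Compound 3 stands only at a limit, > 10000 nM, and so has no exact place on the scale.

Compound 4 `NC(=O)c1ccc(-c2nn(Cc3ccccc3)c3ccccc23)cc1` differs from compound 3 in one place: amino in place of hydroxy on a carbonyl carbon, which turns carboxy into carbamoyl.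

Going by the values given here, no measured pair isolates this change, so any expectation in this assay rests on indirect comparison. Compound 3 is the only one of the three with a free carboxy group. Compound 1 (5650 nM) and compound 2 (670 nM) carry an ester instead and both give numbers, although they also differ from compound 3 elsewhere. On that thin basis, a moderate move towards stronger inhibition is expected, and compound 4 could still end up at the limit. The expected change is an at least 2.0-fold lower number from compound 3 to compound 4 (0.30 log units; that floor lies within the scatter) in the direction of stronger inhibition. For compound 4 the estimated value is 5000 nM, with an expected range of 1500 nM to 15000 nM.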

Compound 4, half-maximal inhibitory concentration: > 10000 nM
Compound 4: no number, only a limit; the forecaster's own chance of this, stated with the estimate: 35%; at least 2.0-fold (0.30 log units) between middle value and limit.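

In this assay, compound 3 and compound 4 each give a limit and not a number, so no step can be read between them: the limit of > 10000 nM in this assay, at which 2 of the 4 values shown sit.

The compounds shown leave open whether carbamoyl in place of carboxy changes inhibition at all on this core, and how much weaker than the limit either compound really is.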